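The source may report more compounds than this note shows. Statements on the series, on what has been measured and on what is new or still open speak of the compounds shown alone.

Measured so far in an assay on cells (Hepatocyte) for inhibition of glucokinase regulatory protein (Mus musculus), with stated times of 20 min and 40 min; on this read-out higher numbers stand for an effect only at larger amounts of compound and lower numbers for an effect already at smaller amounts:
compound 1 `CC#C[C@H]1CN(S(=O)(=O)c2ccc(N)nc2)CCN1c1ccc(S(C)(=N)=O)cc1` gives 704 nM
compound 2 `CC#C[C@H]1CN(S(=O)(=O)c2ccc(N)nc2)CCN1c1ccc(C(O)(CC#N)C(F)(F)F)cc1` gives 219 nM

Among the compounds with values here, compound 2 holds the lowest of the two numbers; the single measured step, a 3.2-fold lower number from compound 1 to compound 2 (0.51 log units; beyond the scatter), separates it from compound 1, beyond the scatter.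

Compound 3 `CC#C[C@H]1CN(S(=O)(=O)c2ccc(N)nc2)CCN1c1ccc([S+](C)[O-])cc1` differs from compound 2 in one place: a group of 3 heavy atoms (1 carbon, 1 oxygen, 1 sulfur; no ring) in place of a group of 9 heavy atoms (4 carbon, 1 nitrogen, 1 oxygen, 3 fluorine; no ring), on an aromatic carbon. The entering group of 3 heavy atoms sits on an aromatic carbon of a six-membered aromatic ring of carbon only, para to a large group, where compound 2 carries its group of 9 heavy atoms.

Within the data shown here, the only step that bears on this is a 3.2-fold lower number from compound 1 to compound 2 (0.51 log units; beyond the scatter), in which a group of 4 heavy atoms containing sulfur was replaced by the larger group; the number fell. Compound 3 moves back to a short sulfur-containing group, so a reversal of much of that step is expected, giving a higher number in this assay. For compound 3 the expected step is a 2.7-fold higher number from compound 2 to compound 3 (0.44 log units; beyond the scatter). Compound 3 is estimated at 600 nM, with a range from 250 nM to 1500 nM.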

Compound 3, half-maximal effective concentration: > 12500 nM
Compound 3: a limit, no number; the forecaster's own chance of this, stated with the estimate: 2%; at least 20-fold (1.31 log units) between middle value and limit.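

In this assay compound 3 gives only a limit, not a number: the limit of > 12500 nM in this assay, at which 1 of the 3 values shown sits.

Within the data shown here, the position on the aromatic carbon, para to a large group, therefore tolerates far less than the one earlier modest step suggested, with an at least 57-fold higher number from compound 2 to compound 3 (1.75 log units; beyond the scatter) when the group of 3 heavy atoms replaces the group of 9 heavy atoms. Short sulfur-containing groups are also not interchangeable here, since an at least 17-fold higher number from compound 1 to compound 3 (1.24 log units; beyond the scatter) separates two groups that differ by a single heavy atom, so a short sulfur-containing group alone does not account for the number in this assay.

The full size of both steps remains open, and the data give no reason for the loss. Also open, on these data alone, is how a methyl sulfone, a primary amide or a carboxylic acid on this aromatic carbon would read in this assay.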